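The compounds below may be only part of what the source reports. "The series", "measured", "known", "first", "only" and "open" are said of these compounds alone.

In an in vitro functional assay on cells for agonist activity at Bombesin receptor subtype-3 (Mus musculus), read by luminescence and calcium flux (on this read-out higher numbers stand for an effect only at larger amounts of compound and lower numbers for an effect already at smaller amounts), compound 1 `CCCCc1cnc(C(CC)Cc2ccc(-c3ccccc3C(=O)O)cc2)[nH]1` gives 340 nM. Compound 2 `N#Cc1ccccc1Cc1cnc(CCc2ccc(-c3ccccc3C(=O)O)cc2)[nH]1` gives 642 nM in this assay, the highest of the two numbers shown, with compound 1 as its nearest neighbour at a gap that lies within the usual scatter. For compound 3 `CCCCc1cnc(Cc2ccc(-c3ccccc3C(=O)O)cc2)[nH]1` this assay reports only a limit, > 10000 nM, and not a number. Compound 4 `O=C(O)c1ccccc1-c1ccc(CCc2ncc(CC3CC3)[nH]2)cc1` has not yet been measured in this assay. It differs from compound 2 in one place: cyclopropyl in place of 2-cyanophenyl on a saturated chain carbon bound to an aromatic carbon. Within the data shown here, no pair of measured compounds shows what this exchange does to the numbers. The expected step from compound 2 to compound 4 is a 3.1-fold higher number from compound 2 to compound 4 (0.49 log units; beyond the scatter), toward a higher number. Compound 4 is therefore estimated at about 2000 nM, within 500 nM to 8000 nM.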

Compound 4, half-maximal effective concentration: 72 nM
Estimate against measurement, compound 4: 28-fold (1.44 log units) above, outside the stated range (below it).
By their numbers in this assay, from the lowest: compound 4; then compounds 1 and 2 (each within the scatter of the next). At a limit, above all of these: compound 3.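

In this assay the exchange of 2-cyanophenyl for cyclopropyl on this saturated chain carbon gives an 8.9-fold lower number from compound 2 to compound 4 (0.95 log units; beyond the scatter) and is the only single change shown here. The six-membered aromatic ring and its nitrile are therefore not needed at this place for a low number, since a three-membered carbon ring serves in their stead. Nothing measured here accounts for the size of this step. As far as these compounds go, it remains open what a plain benzyl without the nitrile or a larger saturated ring such as cyclohexyl would give here. From the compounds shown here alone, whether an amine on this chain would be accepted also remains open.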